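Removing a Fluoro Substituent: Expected Cytotoxicity of Compound 3

The compounds below may be only part of what the source reports. "The series", "measured", "known", "first", "only" and "open" are said of these compounds alone.

The series shares one core, seen in compound 1 `N#Cc1cc2c(Oc3ccccc3OCCn3ccc(=O)[nH]c3=O)cccn2c1` and in compound 2 `N#Cc1cc2c(Oc3ccc(F)cc3OCCn3ccc(=O)[nH]c3=O)cc(Cl)cn2c1`. In an ADME assay on MT2 cells (Homo sapiens) for cytotoxicity, read by MTT assay (on this read-out higher numbers stand for lower toxicity in this test and lower numbers for higher toxicity in this test), compound 1 gives only a limit, > 100000 nM, not a number. In this assay, among the compounds with values here, compound 2 gives 15000 nM, the only number in this set. The other value recorded, that of compound 1, sits at a limit, (the limit of > 100000 nM in this assay, at which 1 of the 2 values shown sits).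

Compound 3 `N#Cc1cc2c(Oc3ccccc3OCCn3ccc(=O)[nH]c3=O)cc(Cl)cn2c1` is not yet measured. It differs from compound 2 in one place, (hydrogen in place of fluoro on an aromatic carbon), with the fluoro leaving and hydrogen entering on the aromatic carbon described. Within the data shown here, no step between two measured compounds is available to show what this change does in this assay.

A change this small is expected to move the read-out little, if at all, and any shift is expected to lie within the scatter of repeated measurements, with a slight lean toward a higher number. The step from compound 2 to compound 3 is estimated at a 1.3-fold higher number from compound 2 to compound 3 (0.12 log units; within the scatter). Compound 3 is accordingly expected to give about 20000 nM in this assay, within a range from 7000 nM to 60000 nM.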

Compound 3, half-maximal cytotoxic concentration: 39000 nM
Compound 3: middle estimate off by 2.0-fold (0.29 log units), on the low side, and the stated range covers the measured number.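

Taking off the fluoro group gives a 2.6-fold higher number from compound 2 to compound 3 (0.41 log units; beyond the scatter), so on this aromatic carbon, meta to a large group and para to a large group, hydrogen in place of fluoro does move the read-out in this assay, toward lower toxicity in this test. Within the data shown here, compound 3 also gives the first readable comparison for the chloro group on its aromatic carbon: chloro in place of hydrogen gives an at least 2.5-fold lower number from compound 1 to compound 3 (0.40 log units; beyond the scatter), so this single change moves the read-out in the opposite direction, toward higher toxicity in this test. The true size of that second step stays unknown, since compound 1 gives only a limit and not a number: the limit of > 100000 nM in this assay, at which 1 of the 3 values shown sits.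

The compounds shown leave open whether the fluoro step would hold on a core without the chloro group, and whether a methoxy group or an amine on the same aromatic carbon would read differently from either fluoro or hydrogen. They also leave open how a bromo or a methyl group in the place of chloro would read in this assay.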